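The source may report more compounds than this note shows. Statements on the series, on what has been measured and on what is new or still open speak of the compounds shown alone.

Compound 1 `COc1cccc(COc2ccc3c(c2)C(C)=CC(C)(C)N3Cc2cccc(OC)c2)c1`, compound 2 `COc1cc(CN2c3ccc(O)cc3C(C)=CC2(C)C)cc(OC)c1` and compound 3 `COc1ccc(CN2c3ccc(O)cc3C(C)=CC2(C)C)cc1` share one core and are compared in an ADME assay on L6 cells (Rattus norvegicus) for cytotoxicity, read by resazurin assay, with a stated time of 70 h; on this read-out lower numbers stand for stronger inhibition and higher numbers for weaker inhibition. For compound 1 this assay reports only a limit, > 210000 nM, so no number stands for that compound. In this assay compound 2 gives 11000 nM. Compound 3 gives 6200 nM in this assay, the lowest of the two numbers recorded in the set; the number for compound 2 sits close to it, and the two lie within the scatter of repeated measurements, so no order between compound 2 and compound 3 can be read from them.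

The step that the account follows leads from compound 3 to compound 4 `COc1ccc(CN2c3ccc(OC(C)=O)cc3C(C)=CC2(C)C)cc1`. The structural change is acetyl in place of hydrogen on an oxygen on an aromatic ring. Going by the values given here, no measured pair in this set makes the same change, so there is no directly comparable step to draw on, and nothing among the measured compounds speaks for a shift in either direction. The expectation is therefore that compound 4 stays within the scatter of compound 3 in this assay. Compound 4 is expected to give about 7000 nM in this assay, within a range from 2500 nM to 25000 nM, which corresponds to an expected step of a 1.1-fold higher number from compound 3 to compound 4 (0.05 log units; within the scatter).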

Compound 4, half-maximal inhibitory concentration: 15000 nM
The estimate for compound 4 lay 2.1-fold (0.33 log units) below the measured number; low and high end bracket the measured number.
By their numbers in this assay, from the lowest: compounds 3, 2 and 4 (each within the scatter of the next, the first and the last beyond it). At a limit, above all of these: compound 1.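

Going by these compounds alone, the step gives this set its only comparison between compounds that differ in one place, which compounds 1, 2 and 3 could not offer among themselves. In this assay, acetyl in place of hydrogen on an oxygen on an aromatic ring gives a 2.4-fold higher number from compound 3 to compound 4 (0.38 log units; beyond the scatter), a modest step that lies beyond the scatter, so on this read-out the change from hydroxy to acetoxy goes with weaker inhibition. At the same time, compound 4 still gives a measured number of 15000 nM rather than a limit, so in this pair the hydrogen on that oxygen is not needed for a number to be read, and nothing given here accounts for the size or direction of the step.

Within the data shown here, whether the same change would give a step of similar size with the other substituents on the shared core, such as the one carried by compound 2, remains open, since the step rests on this single pair. Also open, as far as these compounds go, is how this oxygen would read with a methyl group or a longer acyl chain such as butanoyl in place of the acetyl, or how the position would read with an amine in place of the hydroxy.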